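Ring Configuration Change and Expected Cytotoxicity of Compound 4

The source may hold more compounds than are shown below. What is called first, only, known or untested is meant among the compounds shown, and "the series" means these compounds.

Three compounds have been measured for toxicity to cultured human cells:

compound 1 `CC(C)(C)C#Cc1cc(N(C(=O)[C@H]2CC[C@H](C)CC2)[C@H]2CC[C@H](Oc3ccccn3)CC2)c(C(=O)O)s1` gives 100 nM
compound 2 `CC1=CC[C@H](C(=O)N(c2cc(C#CC(C)(C)C)sc2C(=O)O)[C@H]2CC[C@](O)(CO[C@H]3CCOC3)CC2)CC1` gives 12100 nM
compound 3 `CC(C)(C)C#Cc1cc(N(C(=O)[C@H]2CC[C@H](C)CC2)[C@H]2CC[C@@](O)(CO[C@H]3CCOC3)CC2)c(C(=O)O)s1` gives 18100 nM

These numbers come from an ADME assay on MT4 cells (Homo sapiens) for cytotoxicity, with a stated time of 5 days; on this read-out higher numbers stand for lower toxicity in this test and lower numbers for higher toxicity in this test. Compound 3 has the highest number of the three, meaning the lowest toxicity seen here. Its nearest neighbour is compound 2, whose number lies within the usual scatter of compound 3, so the two cannot be told apart. Compound 1 is far away, with a much lower number than compound 3, a gap well beyond the scatter.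

Compound 4 `CC(C)(C)C#Cc1cc(N(C(=O)[C@H]2CC[C@H](C)CC2)[C@H]2CC[C@](O)(CO[C@H]3CCOC3)CC2)c(C(=O)O)s1` is the next compound. Set against compound 3, (the two compounds have the same atoms and bonds and differ only in configuration as drawn: 3 of 5 stereo elements differ; a stereocentre at a saturated ring carbon is drawn S in compound 3 and R in compound 4; a stereocentre at a saturated ring carbon is drawn S in compound 3 and R in compound 4; a stereocentre at a saturated ring carbon is drawn r in compound 3 and s in compound 4). For the measured compounds named here, no pair of measured compounds differing in a single place is available to show how such a change in drawn configuration moves this read-out. Compound 2 and compound 3, which share the same hydroxy-bearing ring, both give high numbers, so for compound 4 a step of a 1.3-fold lower number from compound 3 to compound 4 (0.11 log units; within the scatter) is expected, which is no change beyond the scatter. Compound 4 is therefore estimated at 14000 nM, with a likely range from 5000 nM to 40000 nM.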

Compound 4, half-maximal cytotoxic concentration in the MT4 assay: 8980 nM
Compound 4: middle estimate off by 1.6-fold (0.19 log units), on the high side, and the stated range covers the measured number.
By their numbers in the MT4 assay, from the lowest: compound 1; then compounds 4, 2 and 3 (each within the scatter of the next).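

For the compounds shown here, in the MT4 assay, the first pair of compounds to differ only in drawn configuration gives a 2.0-fold lower number from compound 3 to compound 4 (0.30 log units; within the scatter), so changing these stereo elements together, including those at saturated ring carbons, produces no difference beyond the scatter. The other new comparison gives a 1.3-fold lower number from compound 2 to compound 4 (0.13 log units; within the scatter), so 4-methylcyclohexyl in place of 4-methylcyclohex-3-en-1-yl on a carbonyl carbon also stays within the scatter. The first of these comparisons isolates configuration from any change in the groups present: the fact that compounds 3 and 4 differ only in the configuration as drawn

From the compounds shown here alone, in a physicochemical assay for lipophilicity (a higher number here means a more lipophilic compound, a lower number a more polar compound), compound 3 stands as "not determined" (no result reported) and compound 4 gives 2.4, so the effect of this configuration change on that read-out stays open. Also open, going by these compounds, are which changed stereo element, taken alone, would alter the numbers in the MT4 assay, and how those numbers would respond to an amine in place of the methyl of the 4-methylcyclohexyl group.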